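Substituent change on the shared core: compound 4

This account rests on a few compounds, and the source may have more. Where it says the series, first, only, none or still open, it means among the compounds named here.

Measured so far:
compound 1 `CCOC(=O)c1cn(C(c2ccccc2)c2cc3cc(Br)ccc3nc2OC)nn1`: 15.4%
compound 2 `COc1nc2ccc(Br)cc2cc1C(c1ccccc1)n1cc(CCO)nn1`: 19.8%
compound 3 `COc1nc2ccc(Br)cc2cc1C(c1ccccc1)n1cc(-c2ccccc2C(F)(F)F)nn1`: 11.4%

In an ADME assay on PANC-1 cells (Homo sapiens) for cytotoxicity, read by sulforhodamine B assay, with a stated time of 48 h, tested at 10 uM (on this read-out lower numbers stand for less inhibition and higher numbers for more inhibition at the one concentration tested (going by the name of the read-out)), compound 1 gives 15.4% and stands second highest of the three numbers, with compound 3 nearest and compound 2 furthest. All three lie within the scatter of one another: a number 4.4 percentage points higher from compound 1 to compound 2 (within the scatter), a number 4 percentage points lower from compound 1 to compound 3 (within the scatter), a number 8.4 percentage points lower from compound 2 to compound 3 (within the scatter).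

Compound 4 `COc1nc2ccc(Br)cc2cc1C(c1ccccc1)n1cc(-c2ccc(F)cc2)nn1` differs from compound 1 by 4-fluorophenyl in place of ethoxycarbonyl on an aromatic carbon. The step from compound 1 to compound 3 is the one that bears on this change, an aromatic ring entering in place of ethoxycarbonyl on the same carbon, and it stayed within the scatter. Among the compounds with values here, no step in the set has moved beyond the scatter, so for compound 4 the expected step in this assay is a number 2.4 percentage points lower from compound 1 to compound 4 (within the scatter), none beyond the scatter. Compound 4 is therefore estimated at 13%, with a range from 3% to 25%.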

Compound 4, a percentage reported as inhibition, at one concentration (the size of the read-out at that concentration, not a potency): 14.9%
The estimate for compound 4 lay 1.9 percentage points below the measured number, and the stated range covers the measured number.
By their numbers in this assay, from the lowest: compounds 3, 4, 1 and 2 (each within the scatter of the next).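

In this assay, 4-fluorophenyl in place of ethoxycarbonyl gives a number 0.5 percentage points lower from compound 1 to compound 4 (within the scatter), and the comparisons with the other two groups give a number 3.5 percentage points higher from compound 3 to compound 4 (within the scatter) and a number 4.9 percentage points lower from compound 2 to compound 4 (within the scatter). This aromatic carbon of the five-membered ring has now carried four groups, including two differently substituted phenyl rings, with no step beyond the scatter, so the flat picture also holds for a para-free reading of 4-fluorophenyl alone. No evidence on the origin of this flat response is available. On these data alone, whether an amine or a carboxylic acid here would give a step beyond the scatter remains open.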